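From 3-bromophenyl to 2-chlorophenyl on a shared core

The compounds below may be only part of what the source reports. "The series", "measured", "known", "first", "only" and "open" are said of these compounds alone.

Compound 1 `C/C(=N\NC(=O)/C(C#N)=C/c1ccccc1)c1c(O)c2ccc(O)cc2oc1=O`, compound 2 `COc1ccc(/C=C(\C#N)C(=O)N/N=C(\C)c2c(O)c3ccc(O)cc3oc2=O)cc1OC` and compound 3 `C/C(=N\NC(=O)/C(C#N)=C/c1cccc(Br)c1)c1c(O)c2ccc(O)cc2oc1=O` share one core and differ in the aromatic group on a double-bonded chain carbon. In a functional assay on SK-N-SH cells (Homo sapiens) for cytotoxicity, read by MTT assay, with a stated time of 24 h (on this read-out higher numbers stand for weaker inhibition and lower numbers for stronger inhibition), compound 1 gives 13500 nM, compound 2 gives 21500 nM and compound 3 gives 31300 nM. The numbers show a 1.5-fold higher number from compound 2 to compound 3 (0.16 log units; within the scatter), but also a 2.3-fold higher number from compound 1 to compound 3 (0.37 log units; beyond the scatter), so compound 3 cannot be separated from compound 2, only from compound 1.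

Compound 4 `C/C(=N\NC(=O)/C(C#N)=C/c1ccccc1Cl)c1c(O)c2ccc(O)cc2oc1=O`, not yet measured, carries 2-chlorophenyl in place of 3-bromophenyl on a double-bonded chain carbon bound to a double-bonded chain carbon. The two steps away from the plain phenyl group of compound 1 bear on this change, and both were small: a 1.6-fold higher number from compound 1 to compound 2 (0.20 log units; within the scatter) and a 2.3-fold higher number from compound 1 to compound 3 (0.37 log units; beyond the scatter). For the measured compounds named here, no chlorinated compound has been measured, so this is only indirect evidence. In this assay a slightly lower number is expected, but no step beyond the scatter, and the expected step is a 1.4-fold lower number from compound 3 to compound 4 (0.15 log units; within the scatter). For compound 4 the estimated value is 22000 nM, with an expected range from 10000 nM to 45000 nM.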

Compound 4, half-maximal inhibitory concentration: 14000 nM
Compound 4: middle estimate off by 1.6-fold (0.20 log units), on the high side; the range from low to high includes it.
By their numbers in this assay, from the lowest: compounds 1, 4, 2 and 3 (each within the scatter of the next, the first and the last beyond it).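

In this assay, for the compounds shown here, the swap at this place is not neutral, even though only one substituent on the ring differs: a 2.2-fold lower number from compound 3 to compound 4 (0.35 log units; beyond the scatter). Chloro in place of hydrogen leaves no measurable mark, with a 1.0-fold higher number from compound 1 to compound 4 (0.02 log units; within the scatter), and compound 4 also stays within the scatter of the dimethoxy compound, with a 1.5-fold lower number from compound 2 to compound 4 (0.19 log units; within the scatter), so adding a halogen does not by itself raise the number, and compound 3 is the only halogen-bearing compound that separates from compound 1. No available measurement bears on why these two halogenated compounds differ.

The swap changes both the halogen and where it sits on the ring, so these compounds cannot show which of the two matters. From the compounds shown here alone, how a phenyl ring carrying an amine or a carboxylic acid would behave at this place also remains open.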